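Swapping an Oxane for a Methylthiazole on the Amide

The source may report more compounds than this note shows. Statements on the series, on what has been measured and on what is new or still open speak of the compounds shown alone.

Compound 1 `CC1CCC(C(=O)N2CCc3nc(C#Cc4ccccc4)sc3C2)CC1` — > 10000 nM
Compound 2 `O=C(C1CCCCO1)N1CCc2nc(C#Cc3ccccc3)sc2C1` — > 10000 nM

Both values come from an assay on HEK293 cells for negative allosteric modulation of metabotropic glutamate receptor 5 (Homo sapiens), read by FLIPR, with a stated time of 1 h; on this read-out lower numbers stand for stronger inhibition and higher numbers for weaker inhibition. For compound 1 the value is a limit of the assay, not a number. For compound 2 the value is likewise a limit, so compound 2 cannot be placed on a scale of potency. Within the data shown here, the single step between the two, a step that the two limits leave unreadable from compound 1 to compound 2, is unreadable for that reason (the limit of > 10000 nM in this assay, at which 2 of the 2 values shown sit).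

Compound 3 `Cc1nc(C(=O)N2CCc3nc(C#Cc4ccccc4)sc3C2)cs1` is the next compound. Its difference from compound 2: 2-methyl-1,3-thiazol-4-yl in place of oxan-2-yl on a carbonyl carbon. Among the measured compounds shown here, no measured step bears on this change, as a step that the two limits leave unreadable from compound 1 to compound 2 gives no size, and both measured values sit at the limit. The step that the limit leaves unreadable from compound 2 to compound 3 is therefore expected to be small, with the value staying near the limit. Compound 3 is estimated at 15000 nM, within a range of 4000 nM to 60000 nM, and most likely reported as a limit again.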

Compound 3, half-maximal inhibitory concentration: > 10000 nM
Compound 3: no number, only a limit; the forecaster's own chance of this, stated with the estimate: 75%; the middle value is on the limit's open side.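

In this assay compound 3 gives > 10000 nM, again a limit and not a number. The steps linking compound 1, compound 2 and compound 3 therefore cannot be read: the limit of > 10000 nM in this assay, at which 3 of the 3 values shown sit. The compounds shown leave open whether any group on this carbonyl gives a readable potency.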